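Chloro on the 1-phenylethenyl compound

The source may report more compounds than this note shows. Statements on the series, on what has been measured and on what is new or still open speak of the compounds shown alone.

In a functional assay on A549 cells (Homo sapiens) for cytotoxicity, read by MTT assay, with a stated time of 48 h (on this read-out higher numbers stand for weaker inhibition and lower numbers for stronger inhibition), compound 3 (`C=C(c1ccccc1)c1cc(OC)c(OC)c(OC)c1-c1ccccc1`) gives 17000 nM and sits within the scatter of compound 1 (`COc1ccc(/C=C/c2cc(OC)c(OC)c(OC)c2-c2ccc(F)c(C)c2)cc1`) at 18000 nM while compound 2 (`COc1cc(/C=C/c2ccc(C)cc2)c(-c2ccccc2)c(OC)c1OC`) reads a higher 54000 nM on this scale. Compound 4 (`C=C(c1ccc(Cl)cc1)c1cc(OC)c(OC)c(OC)c1-c1ccccc1`) turns phenyl into 4-chlorophenyl (chloro in place of hydrogen on an aromatic carbon) on an aromatic carbon, para to a large group. Going by the values given here, only one measured step bears on this, and only loosely: a 3.2-fold lower number from compound 2 to compound 3 (0.50 log units; beyond the scatter) is modest and replaces a whole substituent. Among the compounds with values here, no measured step adds a chloro, so no step beyond the scatter is expected. The estimate in this assay is a slightly lower number, a 1.2-fold lower number from compound 3 to compound 4 (0.08 log units; within the scatter), within the scatter. Compound 4 is estimated at 14000 nM (expected range 6000 nM to 35000 nM) for now.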

Compound 4, half-maximal inhibitory concentration: 40000 nM
For compound 4 the middle estimate is 2.9-fold (0.46 log units) below the measured one; measured number outside the range, above it.
By their numbers in this assay, from the lowest: compounds 3 and 1 (each within the scatter of the next); then compounds 4 and 2 (each within the scatter of the next).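

In this assay, going by these compounds alone, the chloro that enters para to a large group is not neutral: a 2.4-fold higher number from compound 3 to compound 4 (0.37 log units; beyond the scatter) is the first measured step at this position, and it runs toward weaker inhibition. With a 1.4-fold lower number from compound 2 to compound 4 (0.13 log units; within the scatter) inside the scatter, the advantage of 1-phenylethenyl over 2-(4-methylphenyl)ethenyl does not persist once the chloro is present. No evidence at hand explains this shift. Open, going by these compounds, is whether an amine or a carboxylic acid at the same carbon would move the number the same way as chloro, and whether the step depends on this carbon at all.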